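The compounds below may be only part of what the source reports. "The series", "measured", "known", "first", "only" and "open" are said of these compounds alone.

In a functional assay on cells (leukaemia cell line, Homo sapiens) for inhibition, read by sulforhodamine B assay, with a stated time of 48 h (a lower number here means that less compound is tolerated, a higher number that more compound is tolerated), two sulfonamides sharing one core have been measured so far. Compound 1 `O=S(=O)(Nc1ccccc1Cl)c1ccc(-c2cnc(C3CC3)o2)cc1` gives > 100000 nM, which is a limit of the assay and not a number. Compound 2 `O=S(=O)(Nc1ccc(F)cc1F)c1ccc(-c2cnc(C3CC3)o2)cc1` gives > 100000 nM, which is likewise a limit. Compound 2 therefore has no numerical position, and all that is measured here rests on (the limit of > 100000 nM in this assay, at which 2 of the 2 values shown sit).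

Compound 3 `O=S(=O)(Nc1cc(F)cc(F)c1)c1ccc(-c2cnc(C3CC3)o2)cc1` keeps the shared core and carries 3,5-difluorophenyl in place of 2,4-difluorophenyl on a sulfonamide nitrogen. Within the data shown here, only one measured step bears on this change, and it concerns the same place on the molecule: a step that the two limits leave unreadable from compound 1 to compound 2. That step gives no size to carry over, so the expectation rests on the fact that neither measured compound left the limit. No step beyond the scatter is expected, and no direction can be favoured. The expected step is a number no higher from compound 2 to compound 3 (the limit leaves the size open). For compound 3 the estimated value is 100000 nM, with an expected range from 40000 nM to 200000 nM, and the assay is expected most likely to report only a limit again.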

Compound 3, concentration lethal to 50% of the cells: > 100000 nM
Compound 3: no number, only a limit (the forecaster's own chance of this, stated with the estimate: 85%); the middle value lies on the limit itself.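

Compound 3 gives > 100000 nM in this assay, which is a limit of the assay and not a number. Among these compounds, no step among compound 1, compound 2 and compound 3 can be read, and what is measured rests on a single observation: the limit of > 100000 nM in this assay, at which 3 of the 3 values shown sit. The compounds shown leave open where on the numerical scale any of the three lies, and whether a change on the sulfonamide nitrogen alters the value at all.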